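A Sulfur-to-Carbon Swap on an Anilide Phenyl

The compounds below may be only part of what the source reports. "The series", "measured", "known", "first", "only" and "open" are said of these compounds alone.

Among the measured compounds shown here, compound 1, `CSc1cccc(NC(=O)CN2CCC(c3cccc[n+]3[O-])CC2)c1`, is one of three compounds measured in a functional assay on HEK293 cells for agonist activity at D(4) dopamine receptor (Homo sapiens), read by FLIPR; on this read-out lower numbers stand for an effect already at smaller amounts and higher numbers for an effect only at larger amounts of compound. Compound 1 gives 100 nM, the second highest of the three numbers. Compound 2, `C=Cc1cccc(C(=O)NCN2CCC(c3cccc[n+]3[O-])CC2)c1`, gives 68 nM, which lies within the scatter of compound 1. Compound 3, `O=C(NCN1CCC(c2cccc[n+]2[O-])CC1)c1ccccn1`, gives 3150 nM, far beyond the scatter of compound 1.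

For the measured compounds named here, the only step measured between two compounds differing in one place is a 46-fold higher number from compound 2 to compound 3 (1.67 log units; beyond the scatter). It exchanges the whole aryl group on the carbonyl carbon for a ring of another kind, and it says little about the change now in question.

Compound 4, `CCc1cccc(NC(=O)CN2CCC(c3cccc[n+]3[O-])CC2)c1`, differs from compound 1 by ethyl in place of methylsulfanyl on an aromatic carbon. The change keeps the size of the substituent on that six-membered aromatic ring of carbon only and removes one hydrogen-bond acceptor. Going by the values given here, no measured pair shows this kind of exchange. The expectation for compound 4 therefore rests on compound 1 alone, and the step of a 1.2-fold higher number from compound 1 to compound 4 (0.08 log units; within the scatter) is expected to stay within the scatter. Compound 4 is estimated at 120 nM, with a plausible range from 40 nM to 400 nM.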

Compound 4, half-maximal effective concentration: 95 nM
Compound 4: middle estimate off by 1.3-fold (0.10 log units), on the high side, and the stated range covers the measured number.
By their numbers in this assay, from the lowest: compounds 2, 4 and 1 (each within the scatter of the next); then compound 3.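

In this assay, among the compounds shown here, ethyl in place of methylsulfanyl on the aromatic carbon gives a 1.1-fold lower number from compound 1 to compound 4 (0.02 log units; within the scatter), so the two numbers cannot be told apart, and this is the first measured exchange at this position of the six-membered aromatic ring. Compound 4 carries neither the sulfur atom nor the hydrogen-bond acceptor counted for methylsulfanyl, yet it stands within the scatter of compound 1, so neither is needed for a number of this size in this pair. Nothing measured here gives a reason why the two substituents read alike.

As far as these compounds go, it remains open whether the same match would hold for groups of another kind at this position, such as an amine, a carboxylic acid or a longer chain like butyl, or for ethyl moved to another carbon of the ring. Also open, from the compounds shown here alone, is whether a large step such as a 46-fold higher number from compound 2 to compound 3 (1.67 log units; beyond the scatter) would appear if a pyridin-2-yl ring took the place of the substituted phenyl in compound 1 and compound 4, whose amide link differs from that of compound 2.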